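A few compounds are considered here, and "the series" means these few. Any claim that something is new, unique, unknown or untested is made for them only; others in the source may bear on it.

Measured so far in a physicochemical assay for solubility, read by spectrophotometry, in phosphate buffer, measured as kinetic solubility, with a stated time of 18 h, at pH 7.4 (a lower number here means a less soluble compound, a higher number a more soluble compound), are two compounds:

compound 1 `O=C(Nc1ccc(F)c(-c2nc3ccccc3o2)c1)c1cc([N+](=O)[O-])ccc1Cl` gives 270 nM
compound 2 `Cc1ccc(-c2nc3ccccc3s2)cc1NC(=O)c1cc([N+](=O)[O-])c(N2CCC(C(=O)O)CC2)cc1Cl` gives 590 nM

Compound 2 holds the higher of these two numbers, and compound 1 lies below it by more than the scatter. Compound 3 `Cc1ccc(-c2nc3ccccc3s2)cc1NC(=O)c1cc([N+](=O)[O-])c(N(C)C)cc1Cl` follows from compound 2 with dimethylamino in place of 4-carboxypiperidin-1-yl on an aromatic carbon and with nothing else altered. Going by the values given here, no pair of measured compounds differs in one place only, so the data hold no direct precedent for this change. A fall beyond the scatter in this assay is expected. That expectation leans on compound 1, which also lacks 4-carboxypiperidin-1-yl and stands at 270 nM in that measurement. The estimated change is a 2.7-fold lower number from compound 2 to compound 3 (0.43 log units; beyond the scatter) on this reasoning. Compound 3 is estimated at 220 nM with an expected span of 70 nM to 600 nM on this measure.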

Compound 3, solubility: 30 nM
Beside the measured number, compound 3's estimate is 7.3-fold (0.87 log units) above it, and the stated range ends above it.
By their numbers in this assay, from the lowest: compound 3; then compound 1; then compound 2.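

In this assay, dimethylamino in place of 4-carboxypiperidin-1-yl gives a 20-fold lower number from compound 2 to compound 3 (1.29 log units; beyond the scatter), a large step and the first in these data between two compounds that differ in one place. It shows that the number is far from indifferent to the group on this aromatic carbon, ortho to a nitro group and para to a large group, with the rest of the structure unchanged. No measurement shown speaks to the reason for this step.

The compounds shown leave open whether the step follows the carboxylic acid or the six-membered non-aromatic ring, as both leave together here. A plain piperidin-1-yl group without the acid, or a carboxylic acid on an open chain at this carbon, would separate the two.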